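Replacing Diisopropylamino with Piperidin-1-yl: an Expected Outcome

A few compounds are considered here, and "the series" means these few. Any claim that something is new, unique, unknown or untested is made for them only; others in the source may bear on it.

Compound 1 `COc1ccc2occ(CSC(=S)N(C(C)C)C(C)C)c(=O)c2c1` was examined in a functional assay on MCF7 cells (Homo sapiens) for antiproliferative activity, read by MTT assay, with a stated time of 72 h; a higher number here means a weaker inhibitor, a lower number a stronger inhibitor. In this assay compound 1 reaches only the limit of > 40000 nM, so no number is known for it. Compound 2 `CC(C)N(C(=S)SCc1coc2ccccc2c1=O)C(C)C` likewise gives only the limit of > 30000 nM in this assay. The change from compound 1 to compound 2, hydrogen in place of methoxy on an aromatic carbon, is a step that the two limits leave unreadable from compound 1 to compound 2. Compound 3 `COc1ccc2occ(CSC(=S)N3CCCCC3)c(=O)c2c1` differs from compound 1 by piperidin-1-yl in place of diisopropylamino on a thiocarbonyl carbon. Among the measured compounds shown here, no measured step touches this change, and both measured compounds sit at limits. Compound 3 is therefore expected to show a step of a number no higher from compound 1 to compound 3 (the limit leaves the size open), most likely ending again at a limit. Compound 3 is estimated at 40000 nM, between 8000 nM and 150000 nM.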

Compound 3, half-maximal inhibitory concentration: > 40000 nM
Compound 3 gave a limit, no number; the forecaster's own chance of this, stated with the estimate: 70%; the middle value sits exactly at the limit.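

Compound 1 and compound 3 both give only limits in this assay, so the step of piperidin-1-yl in place of diisopropylamino cannot be read. The compounds shown leave open what actual number any of them would reach.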